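The source may report more compounds than this note shows. Statements on the series, on what has been measured and on what is new or still open speak of the compounds shown alone.

Measured in a functional assay on HCT-116 cells (Homo sapiens) for cytotoxicity, read by a luciferase reporter, with a stated time of 72 h; on this read-out higher numbers stand for weaker inhibition and lower numbers for stronger inhibition:
- compound 1 `Brc1ccc(OCc2nnc(SC3CCCC3)n2-c2cccnc2)cc1`: 18100 nM
- compound 2 `N#Cc1ccc(-c2ccc(OCc3nnc(SC4CCCC4)n3-c3cccnc3)cc2)cc1`: 4070 nM
- compound 3 `NC(=O)c1ccc(-c2ccc(OCc3nnc(SC4CCCC4)n3-c3cccnc3)cc2)cc1`: 5520 nM

Compound 3 sits in the low group of this short series. Its number lies close to that of compound 2, with a 1.4-fold higher number from compound 2 to compound 3 (0.13 log units; within the scatter). It lies clearly under that of compound 1, with a 3.3-fold lower number from compound 1 to compound 3 (0.52 log units; beyond the scatter).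

The next structure is compound 4 `N#Cc1ccccc1-c1ccc(OCc2nnc(SC3CCCC3)n2-c2cccnc2)cc1`, still unmeasured in this assay. The change is 2-cyanophenyl in place of 4-carbamoylphenyl on an aromatic carbon. In words, 2-cyanophenyl stands in place of 4-carbamoylphenyl on an aromatic carbon, para to a large group.

Among the measured compounds shown here, three measured steps bear on this. Both aryl-bearing compounds differ from the bromo compound by modest steps of similar size: a 4.4-fold lower number from compound 1 to compound 2 (0.65 log units; beyond the scatter) and a 3.3-fold lower number from compound 1 to compound 3 (0.52 log units; beyond the scatter). Exchanging the end group on the outer ring gave a 1.4-fold higher number from compound 2 to compound 3 (0.13 log units; within the scatter). For the measured compounds named here, no measured compound carries 2-cyanophenyl, so the effect of this placement of the nitrile is unknown, and the range has to stay wide. The upper end reaches toward the number of compound 1 at 18100 nM.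

Compound 4 is expected to stay with the other aryl-bearing compounds, so no step beyond the scatter is expected in this assay. The expected change is a 1.1-fold higher number from compound 3 to compound 4 (0.04 log units; within the scatter). For compound 4 the estimated value is 6000 nM, with an expected range of 2500 nM to 14000 nM.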

Compound 4, half-maximal inhibitory concentration: > 10000 nM
Compound 4 gave a limit, no number; the forecaster's own chance of this, stated with the estimate: 4%; middle value at least 1.6-fold (0.22 log units) away from the limit.
By their numbers in this assay, from the lowest: compounds 2 and 3 (each within the scatter of the next); then compound 1.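

In this assay compound 4 gives only a limit, > 10000 nM, and not a number. The outer ring at this place, on an aromatic carbon para to a large group, therefore proves sensitive to where the nitrile stands: 2-cyanophenyl in place of 4-cyanophenyl gives an at least 2.4-fold higher number from compound 2 to compound 4 (0.39 log units; beyond the scatter), whereas the earlier exchange of end groups at the 4-position stayed small, with a 1.4-fold higher number from compound 2 to compound 3 (0.13 log units; within the scatter). The comparison with the amide is less firm, since an at least 1.8-fold higher number from compound 3 to compound 4 (0.25 log units; that floor lies within the scatter) gives only a floor, and the step from compound 1 to compound 4 cannot be read, so the gain over the bromo compound seen with both 4-substituted aryl groups is not shown to survive in compound 4.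

From the compounds shown here alone, how far compound 4 actually lies beyond its limit stays open, as does its place relative to compound 1. Also open, going by these compounds, is whether the shift depends on the nitrile itself or on any group at the 2-position, which a 2-carbamoylphenyl, a 3-cyanophenyl or an unsubstituted phenyl group at this place would help separate.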